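The source may hold more compounds than are shown below. What is called first, only, known or untested is meant among the compounds shown, and "the series" means these compounds.

This study follows a small set of related compounds in a toxicity assay on Vero cells (Chlorocebus sabaeus) for inhibition; on this read-out higher numbers stand for an effect only at larger amounts of compound and lower numbers for an effect already at smaller amounts. The starting point is compound 1 `COc1cccc(NC(=O)c2nnn(Cc3ccc(SC)cc3)c2N)c1`. In this assay compound 1 gives only a limit, > 50100 nM, and not a number. Compound 3 `COc1cccc(NC(=O)c2nnn(CC3CCN(C(=O)OC(C)(C)C)CC3)c2N)c1` likewise returns only a limit in this assay, > 50100 nM. Among the compounds with values here, compound 2 `COc1cccc(NC(=O)c2nnn(C(CO)c3ccc(C(C)C)cc3)c2N)c1` is the one member with a measured number in this assay, 12600 nM. Compound 1 thus stands at the ceiling of what this assay can report, a position shared with the limit of > 50100 nM in this assay, at which 2 of the 3 values shown sit.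

The compound still to be measured is compound 4 `COc1cccc(NC(=O)c2nnn(Cc3ccncc3)c2N)c1`. It differs from compound 1 in one place: pyridin-4-yl in place of 4-(methylsulfanyl)phenyl on a saturated chain carbon bound to an aromatic nitrogen. Within the data shown here, no pair of measured compounds shows what such an exchange does in this assay, so the expectation for compound 4 rests on where compound 1 stands. The expected step is a number no higher from compound 1 to compound 4 (the limit leaves the size open), most likely none beyond the usual scatter. Compound 4 is therefore expected to give about 50000 nM in this assay, within a range from 20000 nM to 120000 nM, and it may well come back as a limit once more.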

Compound 4, half-maximal effective concentration: > 50100 nM
Compound 4: only a limit was reported; the forecaster's own chance of this, stated with the estimate: 70%; middle value at least 1.0-fold (0.00 log units) from the limit.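

Within the data shown here, compound 1 and compound 4 both return only a limit in this assay, so no step between them can be read: the limit of > 50100 nM in this assay, at which 3 of the 4 values shown sit.

The compounds shown leave open whether pyridin-4-yl in place of 4-(methylsulfanyl)phenyl changes the read-out at all, and by how much.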